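The source may report more compounds than this note shows. Statements on the series, on what has been measured and on what is new or still open speak of the compounds shown alone.

Compound 1, `Cc1cc(C)cc(S(=O)(=O)c2c(C(=O)N[C@H]3CCN(Cc4ccccc4F)C3)[nH]c3ccc(Cl)cc23)c1`: in an ADME assay on MT4 cells (Homo sapiens) for cytotoxicity, read by MTT assay, with a stated time of 5 days (a lower number here means that less compound is tolerated, a higher number that more compound is tolerated), compound 1 gives 215000 nM.
Compound 2, `Cc1cc(C)cc(S(=O)(=O)c2c(C(=O)N[C@H]3CCN(Cc4ccccc4C#N)C3)[nH]c3ccc(Cl)cc23)c1`: compound 2 gives only a limit of this assay, > 228000 nM.
Compound 3, `Cc1cc(C)cc(S(=O)(=O)c2c(C(=O)NC3CN(Cc4ccccc4F)C3)[nH]c3ccc(Cl)cc23)c1`: compound 3 likewise gives only a limit, > 238000 nM.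

Compound 3 thus stands at a limit of this assay rather than at a number, (the limit of > 238000 nM in this assay, at which 1 of the 3 values shown sits). Among the compounds with values here, the only measured step, an at least 1.0-fold higher number from compound 1 to compound 2 (0.02 log units; that floor lies within the scatter), concerns a substituent on an aromatic carbon and lies within the scatter. Compound 4, `Cc1cc(C)cc(S(=O)(=O)c2c(C(=O)NS(=O)(=O)c3ccccc3)[nH]c3ccc(Cl)cc23)c1`, differs from compound 3 by phenylsulfonyl in place of 1-(2-fluorobenzyl)azetidin-3-yl on an amide-type nitrogen, a change at a different place from the measured step, which therefore offers little guidance. No step beyond the scatter is expected, an at least 1.1-fold lower number from compound 3 to compound 4 (0.07 log units; that floor lies within the scatter). Compound 4 is estimated to give 200000 nM, in a range from 80000 nM to 300000 nM, and a further limit rather than a number is quite possible.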

Compound 4, half-maximal cytotoxic concentration: 167000 nM
Estimate against measurement, compound 4: 1.2-fold (0.08 log units) above; measured number inside the range.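

Within the data shown here, exchanging 1-(2-fluorobenzyl)azetidin-3-yl for phenylsulfonyl on the amide-type nitrogen gives the first step at this place, and it replaces the whole group, four-membered ring included: an at least 1.4-fold lower number from compound 3 to compound 4 (0.15 log units; that floor lies within the scatter). Unlike the aromatic substituent step, this one alters the group attached directly to the amide-type nitrogen. Compound 3 stands at a limit, so the full size of this step cannot be read: the limit of > 238000 nM in this assay, at which 1 of the 4 values shown sits.

Going by these compounds, how a simple amine, a carboxylic acid or a longer alkyl chain on this nitrogen would read in this assay remains open.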